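A few compounds are considered here, and "the series" means these few. Any claim that something is new, unique, unknown or untested is made for them only; others in the source may bear on it.

The compounds measured so far:
compound 1, `CCCCC[Se]c1nc([Se]CCCCC)c2cccnc2n1`, > 100000 nM
compound 2, `CSc1ccc(CNc2nc(SC)nc3ncccc23)cc1`, 4320 nM
compound 3, `CCCCC[Se]c1nc([Se]CCCCC)c2ccccc2n1`, > 100000 nM

In a functional assay on HT-29 cells (Homo sapiens) for cytotoxicity, read by MTT assay, with a stated time of 72 h (a lower number here means a stronger inhibitor of growth, a higher number a weaker inhibitor of growth), compound 3 gives only a limit, > 100000 nM, and not a number. Compound 1 likewise gives only a limit in this assay, > 100000 nM. Of the three values shown, two sit at the limit of > 100000 nM in this assay, at which 2 of the 3 values shown sit. Within the data shown here, compound 2, which carries a benzylamino group on its core, gives 4320 nM in this assay, the only number among the three. So compound 3 stands at the limit of this assay, and its place relative to the other compounds cannot be read from the numbers.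

Compound 4, `CCCCC[Se]c1nc(NCc2ccccc2)c2ccccc2n1`, is not yet measured. It differs from compound 3 by a group of 8 heavy atoms (7 carbon, 1 nitrogen; one six-membered aromatic ring of carbon only) in place of a group of 6 heavy atoms (5 carbon, 1 selenium; no ring), on an aromatic carbon. Among the measured compounds shown here, no step between two measured compounds that differ in one place is available, so the size of this change can be judged only from the benzylamino group that compound 4 shares with compound 2, which gives 4320 nM. On that footing compound 4 is expected to move out of the limit and give a number, a step of an at least 5.0-fold lower number from compound 3 to compound 4 (0.69 log units; beyond the scatter) toward stronger inhibition of growth, though the estimate is loose. Compound 4 is expected to give about 20000 nM, with a range from 3000 nM to 100000 nM, and a real chance that this assay again reports only a limit.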

Compound 4, concentration for 50% growth inhibition: 72700 nM
For compound 4 the middle estimate is 3.6-fold (0.56 log units) below the measured one; the measured number falls inside the stated range.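

In this assay, benzylamino in place of the group of 6 heavy atoms (5 carbon, 1 selenium), on an aromatic carbon next to the ring nitrogen, amounts to an at least 1.3-fold lower number from compound 3 to compound 4 (0.13 log units; that floor lies within the scatter). Compound 3 gives > 100000 nM, which is a limit of the assay and not a number. The step is therefore only a floor, and its true size cannot be read, but the exchange does show that this one position can carry the benzylamino group and turn a result at the limit into a measured number, even with the second selenium-bearing group still in place: the limit of > 100000 nM in this assay, at which 2 of the 4 values shown sit.

The compounds shown leave open whether benzylamino is special at this position or whether another amine, such as morpholine or a simple alkylamine, or a shorter chain on an oxygen or sulfur atom, would also give a number in this assay. They also leave open what happens to compound 4 when its remaining group of 6 heavy atoms gives way to a shorter chain or a carboxylic acid, and so how much that group contributes to the growth inhibition.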